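Working notes: compound 1 to compound 3 in cytotoxicity

The compounds below may be only part of what the source reports. "The series", "measured", "known", "first", "only" and "open" are said of these compounds alone.

Measured in a toxicity assay on MCF-10A cells (Homo sapiens) for cytotoxicity, read by MTT assay, with a stated time of 48 h; on this read-out higher numbers stand for weaker inhibition and lower numbers for stronger inhibition:
compound 1 `O=C(/C=C/c1ccc2c(c1)B(O)OC2)c1cccnc1` gives 34400 nM
compound 2 `O=C(/C=C/c1ccc2c(c1)B(O)OC2)c1ccc(Cl)c(Cl)c1` gives 14900 nM

Compound 1 holds the highest number of the two; compound 2 sits at a lower number, a gap beyond the scatter. Compound 3 `O=C(/C=C/c1ccc2c(c1)B(O)OC2)c1ccccc1O` has not yet been run in this assay. It differs from compound 1 by 2-hydroxyphenyl in place of pyridin-3-yl on a carbonyl carbon. For the measured compounds named here, no pair of measured compounds shares this change, so nothing here sets its size. The expectation is a small step toward a lower number, likely within the scatter. For compound 3 the estimated value is 25000 nM, with a range from 8000 nM to 70000 nM, which means an expected step of a 1.4-fold lower number from compound 1 to compound 3 (0.14 log units; within the scatter).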

Compound 3, half-maximal inhibitory concentration: 53700 nM
Beside the measured number, compound 3's estimate is 2.1-fold (0.33 log units) below it; the range from low to high includes it.
By their numbers in this assay, from the lowest: compound 2; then compounds 1 and 3 (each within the scatter of the next).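

In this assay, putting 2-hydroxyphenyl in place of pyridin-3-yl on a carbonyl carbon gives a 1.6-fold higher number from compound 1 to compound 3 (0.19 log units; within the scatter). This position therefore accepts a carbon-only aromatic ring carrying a hydrogen-bond donor without a step that this read-out can separate from the scatter, so compound 1 and compound 3 cannot be told apart here. Nothing available bears on why the two groups read alike.

Still open, on these data alone, is whether an amine or a carboxylic acid on the same carbonyl carbon would give a step beyond the scatter.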